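Notes on the step from compound 3 to compound 4

The source may report more compounds than this note shows. Statements on the series, on what has been measured and on what is new or still open speak of the compounds shown alone.

Of the compounds shown here, three have been measured in an assay on CHO-K1 cells for antagonist activity at transient receptor potential cation channel subfamily V member 1 (Homo sapiens), read by FLIPR and calcium flux, with a stated time of 6 min; a higher number here means a weaker inhibitor, a lower number a stronger inhibitor. Compound 1 `Cn1ncc2cc(NC(=O)NCc3cc(C(F)(F)F)nn3-c3cccc(Cl)c3)ccc21` gives 61 nM in this assay. Compound 2 `CC(=O)n1ncc2c(NC(=O)NCc3cc(C(C)(C)C)nn3-c3cccc(Cl)c3)cccc21` gives 29.5 nM in this assay. Compound 3 `O=C(NCc1cc(C(F)(F)F)nn1-c1cccc(C(F)(F)F)c1)Nc1cccc2[nH]ncc12` gives 1.3 nM in this assay, the lowest of the three numbers; its nearest neighbour is compound 2, its furthest is compound 1, and both gaps lie beyond the scatter, so compound 3 is the strongest inhibitor of the three.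

Compound 4 `O=C(NCc1cc(C(F)(F)F)nn1-c1ccc(F)c(Cl)c1)Nc1cccc2[nH]ncc12` has not been measured. It differs from compound 3 by 3-chloro-4-fluorophenyl in place of 3-(trifluoromethyl)phenyl on an aromatic nitrogen. Going by the values given here, no pair of measured compounds differs in one place, so no measured step covers this exchange. Both the leaving and the entering group are a six-membered aromatic ring of carbon only with no hydrogen-bond donors or acceptors, and only a small step is expected, most likely toward a slightly higher number, possibly none beyond the scatter. Compound 4 is expected to give 2.5 nM in this assay, with a range of 0.8 nM to 8 nM. The expected step is a 1.9-fold higher number from compound 3 to compound 4 (0.28 log units; within the scatter).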

Compound 4, inhibition constant: 0.6 nM
Estimate against measurement, compound 4: 4.2-fold (0.62 log units) above; measured number below the stated range.
By their numbers in this assay, from the lowest: compound 4; then compound 3; then compound 2; then compound 1.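

Going by these compounds alone, on an aromatic nitrogen of the five-membered ring, replacing 3-(trifluoromethyl)phenyl with 3-chloro-4-fluorophenyl gives a 2.2-fold lower number from compound 3 to compound 4 (0.34 log units; beyond the scatter) in this assay, the first one-place comparison. This modest step shows that, with the rest of compound 3 held constant, the position responds to a change in the substituents on the phenyl ring, and that the trifluoromethyl group is not required there for a low nanomolar number. Nothing available explains why the number falls with this exchange.

The exchange removes one substituent and introduces two, so the shares of the chlorine and the fluorine in the step remain unresolved. Also open, going by these compounds, is how this position would respond to a phenyl bearing a methoxy group or a nitrile, or to a pyridine ring in place of the phenyl.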